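Acetylation of a secondary hydroxyl in a diterpenoid lactone series

The source may hold more compounds than are shown below. What is called first, only, known or untested is meant among the compounds shown, and "the series" means these compounds.

Three analogues sharing the same core have been measured in a functional assay on HL-60 cells (Homo sapiens) for cytotoxicity, read by MTT assay, with a stated time of 72 h; a lower number here means a stronger inhibitor, a higher number a weaker inhibitor. Compound 1 `CC(=O)O[C@@H]1C[C@@H](C)[C@](O)(CCC2=CC(=O)OC2)[C@@]2(C)CCCC(C)(C)[C@H]12` reaches only the limit of this assay, < 5 ug/mL. Compound 2 `C[C@@H]1C[C@@H](O)[C@H]2C(C)(C)CCC[C@]2(C)[C@@]1(O)CCC1=CC(=O)OC1` likewise gives a limit, < 5 ug/mL. Compound 3 `C[C@@H]1C[C@@H](O)[C@H]2C(C)(C)CCC[C@]2(C)[C@@]12CC[C@]1(COC(=O)C1)O2` also gives a limit, < 5 ug/mL. Its core is joined differently from that of compound 2, and the difference between the two cores is not broken down here. The step that the two limits leave unreadable from compound 2 to compound 1 comes from acetyl in place of hydrogen on an oxygen on a saturated carbon, and its size cannot be read because of the limit of < 5 ug/mL in this assay, at which 3 of the 3 values shown sit. Compound 4 `CC(=O)O[C@@H]1C[C@@H](C)[C@]2(CC[C@]3(COC(=O)C3)O2)[C@@]2(C)CCCC(C)(C)[C@H]12` differs from compound 3 by the same kind of change, (acetyl in place of hydrogen on an oxygen on a saturated carbon), at a place described in the same words. The step from compound 3 to compound 4 is expected to be a step that the limit leaves unreadable from compound 3 to compound 4, resting on compound 3 at < 5 ug/mL and on the unreadable step from compound 2 to compound 1. Compound 4 is therefore expected to give about 2 ug/mL in this assay, likely again as a limit.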

Compound 4, half-maximal inhibitory concentration: < 5 ug/mL
Compound 4 ended at the assay's limit (the forecaster's own chance of this, stated with the estimate: 80%); the middle value lies beyond the limit too.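

Compound 3 and compound 4 both sit at a limit in this assay, so no new step can be read between them: the limit of < 5 ug/mL in this assay, at which 4 of the 4 values shown sit.

The compounds shown leave open how far past that limit each lies, and so whether hydroxy to acetoxy changes the read-out at all.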